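The compounds below may be only part of what the source reports. "The series", "measured", "known", "first", "only" and "open" are said of these compounds alone.

Compound 1 `CN1CCc2c(sc(NC(=O)c3ccc(Cl)cc3)c2C(N)=O)C1`: 38.5%
Compound 2 `NC(=O)c1c(NC(=O)c2ccc(Cl)cc2)sc2c1CCN(Cc1ccccc1)C2`: 11.1%
Compound 3 `CN1CCc2c(sc(NC(=O)c3ccc(Oc4ccccc4)cc3)c2C(N)=O)C1`: 58.9%

In an ADME assay on RAW264.7 cells (Mus musculus) for cytotoxicity, read by MTT assay, with a stated time of 48 h, tested at 50 uM (on this read-out lower numbers stand for less inhibition and higher numbers for more inhibition at the one concentration tested (going by the name of the read-out)), compound 3 stands highest of the three numbers, with a number 20.4 percentage points higher from compound 1 to compound 3 (beyond the scatter) beyond the scatter, and compound 2 lies lower still. Compound 4 `NC(=O)c1c(NC(=O)c2ccc(Oc3ccccc3)cc2)sc2c1CCN(Cc1ccccc1)C2` differs from compound 3 in one place: phenyl in place of hydrogen on a saturated chain carbon bound to an amine nitrogen in a ring. The same change has been measured once, from compound 1 to compound 2, where a number 27.4 percentage points lower from compound 1 to compound 2 (beyond the scatter) followed. Among the measured compounds shown here, only that single step bears on the move to compound 4, so a drop of similar size is expected in this assay, namely a number 27.4 percentage points lower from compound 3 to compound 4 (beyond the scatter). Compound 4 is therefore estimated at 31.5%, with a range from 15% to 48%.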

Compound 4, a percentage reported as inhibition, at one concentration (the size of the read-out at that concentration, not a potency): 23.6%
The estimate for compound 4 lay 7.9 percentage points above the measured number; low and high end bracket the measured number.
By their numbers in this assay, from the lowest: compound 2; then compound 4; then compound 1; then compound 3.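

In this assay, phenyl in place of hydrogen on a saturated chain carbon bound to an amine nitrogen in a ring now also goes with a number 35.3 percentage points lower from compound 3 to compound 4 (beyond the scatter), so the fall is seen with both the chloro and the phenoxy groups: the same change on two cores in this assay, a number 27.4 percentage points lower (beyond the scatter) from compound 1 to compound 2 and a number 35.3 percentage points lower (beyond the scatter) from compound 3 to compound 4, 7.9 percentage points apart, within the scatter of two such steps. Phenoxy in place of chloro on an aromatic carbon likewise goes with a number 12.5 percentage points higher from compound 2 to compound 4 (beyond the scatter) on the benzyl core: the same change on two cores in this assay, a number 20.4 percentage points higher (beyond the scatter) from compound 1 to compound 3 and a number 12.5 percentage points higher (beyond the scatter) from compound 2 to compound 4, 7.9 percentage points apart, within the scatter of two such steps. Across these four compounds, each change therefore moves the number the same way on both cores.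

As far as these compounds go, it remains open whether a longer chain or a carboxylic acid in the benzyl place would lower the number as well. From the compounds shown here alone, it is also open whether an amine in place of phenoxy would raise it.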